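Extending the methylamino group of compound 2

The source may report more compounds than this note shows. Statements on the series, on what has been measured and on what is new or still open speak of the compounds shown alone.

Compound 2 `CNc1nc(NCc2ccc(C(=O)Nc3ccc(F)cc3)cc2)c2ccccc2n1` was tested in a functional assay on SW480 cells (Homo sapiens) for inhibition, read by luminescence and resazurin assay, with a stated time of 3 days (a lower number here means a stronger inhibitor, a higher number a weaker inhibitor), and gave 4100 nM. That number stands second highest of the three measured here. Its nearest neighbour is compound 1 `CNc1nc(NCc2ccc(NS(=O)(=O)c3ccc(F)cc3)cc2)c2ccccc2n1`, which in this assay gave 4800 nM, a gap within the scatter, while compound 3 `CNc1nc(NCc2ccc(NC(=O)c3ccc(F)cc3)cc2)c2ccccc2n1`, with 2000 nM in this assay, lies beyond the scatter below it. The two measured steps both concern the group that carries the 4-fluorophenyl ring: a 2.4-fold lower number from compound 1 to compound 3 (0.38 log units; beyond the scatter) and a 2.1-fold lower number from compound 2 to compound 3 (0.31 log units; beyond the scatter). Compound 4 `CCCNc1nc(NCc2ccc(C(=O)Nc3ccc(F)cc3)cc2)c2ccccc2n1` differs from compound 2 elsewhere: ethyl in place of hydrogen on a saturated chain carbon bound to a nitrogen on an aromatic ring. Cut one bond further out, the same difference reads methylamino to propylamino. Neither measured step touches that methylamino group, so no comparison among the measured compounds bears directly on this change, and the two steps that do exist give no hint of how a longer chain at this position would be received. With nothing pointing either way, the expectation for compound 4 in this assay is a step no larger than the scatter, a 1.0-fold lower number from compound 2 to compound 4 (0.01 log units; within the scatter). Compound 4 is therefore estimated at 4000 nM in this assay, with a range from 1500 nM to 11000 nM that allows for an unmeasured shift in either direction.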

Compound 4, half-maximal inhibitory concentration: 1600 nM
Estimate against measurement, compound 4: 2.5-fold (0.40 log units) above; the range from low to high includes it.
By their numbers in this assay, from the lowest: compounds 4 and 3 (each within the scatter of the next); then compounds 2 and 1 (each within the scatter of the next).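

For the compounds shown here, the methylamino group of compound 2 proves open to change in this assay, where the step to propylamino gives a 2.6-fold lower number from compound 2 to compound 4 (0.41 log units; beyond the scatter) and so shows that this end of the molecule also affects the number, whereas the earlier steps concerned only the group carrying the 4-fluorophenyl ring. The added ethyl is accepted at this place on the saturated chain carbon, and the number moves down rather than up, by a modest amount that nonetheless lies beyond the scatter. Nothing available explains why this longer chain gives the lower number.

The compounds shown leave open whether an ethylamino or butylamino group, a branched chain such as isopropyl, or a chain ending in an amine or a carboxylic acid would take the number further down or reverse the step. They also leave open whether the same change from methylamino to propylamino would give a similar step on compound 1 or compound 3, which carry the 4-fluorophenyl ring through different groups.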